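Dichloro substitution on the anilino ring of compound 1

A few compounds are considered here, and "the series" means these few. Any claim that something is new, unique, unknown or untested is made for them only; others in the source may bear on it.

Compound 1 `COc1cccc(/C=C/C(=O)c2sc(Nc3ccccc3)nc2C)c1` is one of two measured members of this set. In a functional assay on BGC-823 cells (Homo sapiens) for cytotoxicity, read by MTT assay (on this read-out lower numbers stand for stronger inhibition and higher numbers for weaker inhibition), compound 1 gives 14300 nM, the lowest of the two numbers, with compound 2 `Cc1nc(Nc2ccccc2)sc1C(=O)/C=C/c1ccccc1Cl` nearest to it; in this assay compound 2 gives 22800 nM. Within the data shown here, the only measured step, a 1.6-fold higher number from compound 1 to compound 2 (0.20 log units; within the scatter), concerns 2-chlorophenyl in place of 3-methoxyphenyl on a double-bonded chain carbon bound to a double-bonded chain carbon, and it stays within the scatter.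

Compound 3 `COc1cccc(/C=C/C(=O)c2sc(Nc3ccc(Cl)c(Cl)c3)nc2C)c1` differs from compound 1 elsewhere: 3,4-dichlorophenyl in place of phenyl on a nitrogen on an aromatic ring, that is, anilino to (3,4-dichlorophenyl)amino. Among the measured compounds shown here, no measured step touches this ring, so the single step on record gives no direct guidance on its direction. For the measured compounds named here, the one change that was measured left this assay essentially unchanged, and on that basis a step of no size beyond the scatter is expected here, with a wide range to cover the absence of a comparable step.

Compound 3 is therefore expected to give 12000 nM (range 3500 nM to 40000 nM), an expected step of a 1.2-fold lower number from compound 1 to compound 3 (0.08 log units; within the scatter) from compound 1.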

Compound 3, half-maximal inhibitory concentration: 8350 nM
Compound 3: the middle estimate sits 1.4-fold (0.16 log units) above what was measured, within the range that was stated.
By their numbers in this assay, from the lowest: compounds 3, 1 and 2 (each within the scatter of the next, the first and the last beyond it).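

The anilino ring now has a measured step of its own: in this assay, 3,4-dichlorophenyl in place of phenyl on a nitrogen on an aromatic ring gives a 1.7-fold lower number from compound 1 to compound 3 (0.23 log units; within the scatter). This position therefore tolerates two added chlorine atoms, with the read-out remaining within the scatter of compound 1, and the change adds heavy atoms while the counts of hydrogen-bond donors and acceptors on the group stay at zero. With this step, the two single changes on record from compound 1, one on the aryl group of the chain and one on the group on the nitrogen, both lie within the scatter, so neither identifies a site where this assay responds clearly; no measurement here bears on the cause of this outcome.

Still open, on these data alone, is whether the anilino ring responds at all to groups of a different kind, such as a carboxylic acid, an amine or a methoxy group, and whether a single chlorine reads the same as the pair. Also open, as far as these compounds go, is how the 2-chlorophenyl group on the chain and the 3,4-dichlorophenyl group behave together in one molecule.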